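From Methoxy to Ethoxy on a Shared Core

The compounds below may be only part of what the source reports. "The series", "measured", "known", "first", "only" and "open" are said of these compounds alone.

Compounds and their values in a functional assay on DMS-273 cells (Homo sapiens) for cytotoxicity; on this read-out higher numbers stand for weaker inhibition of growth and lower numbers for stronger inhibition of growth:
- compound 1 `CCc1ccc(/N=C/c2cc(OC)c(OC)c(OC)c2)cc1`: > 100000 nM (a limit)
- compound 2 `COc1ccc(/N=C/c2cc(OC)c(OC)c(OC)c2)cc1`: 33000 nM
- compound 3 `CCOc1ccc(/N=C/c2cc(OC)c(OC)c(OC)c2)cc1`: not yet measured

So far, compound 2 gives the only real number, 33000 nM. Compound 1 gives > 100000 nM, which is a limit of the assay and not a number.

Compound 3 differs from compound 2 by a single change, (methyl in place of hydrogen on a saturated chain carbon bound to an oxygen on an aromatic ring), which turns methoxy into ethoxy. Among the measured compounds shown here, the only measured step that bears on this is an at least 3.0-fold lower number from compound 1 to compound 2 (0.48 log units; beyond the scatter), with methoxy in place of ethyl on an aromatic carbon. From the compounds shown here alone, its full size is unknown, as one end is a limit, and it is a different swap, so it offers only a loose guide. Compound 3 keeps the oxygen on the aromatic ring, so in this assay it is expected to stay near compound 2 at 33000 nM, with no step beyond the scatter. The expected change is a 1.2-fold higher number from compound 2 to compound 3 (0.08 log units; within the scatter). For compound 3 the estimated value is 40000 nM, with an expected range from 13000 nM to 100000 nM.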

Compound 3, concentration for 50% growth inhibition: > 100000 nM
Compound 3 was reported as a limit; the forecaster's own chance of this, stated with the estimate: 25%; at least 2.5-fold (0.39 log units) between middle value and limit.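

Keeping the oxygen on the aromatic ring did not preserve the growth inhibition. In this assay, methyl in place of hydrogen on a saturated chain carbon bound to an oxygen on an aromatic ring, which turns methoxy into ethoxy, gives an at least 3.0-fold higher number from compound 2 to compound 3 (0.48 log units; beyond the scatter), a shift towards weaker inhibition of growth from a very small change. Compound 3 gives > 100000 nM, which is a limit of the assay and not a number, so only the lower bound of this step is known, and the step between compound 1 and compound 3 cannot be read, as both compounds sit at the same limit: the limit of > 100000 nM in this assay, at which 2 of the 3 values shown sit.

The compounds shown leave open whether a longer chain, such as propoxy, would behave like ethoxy, and whether a hydroxyl or an amine in place of the methoxy would move the number of compound 2 in either direction. They also leave open how far compound 3 truly lies from compound 2, and how sharply this read-out responds to small changes at this position.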